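The source may report more compounds than this note shows. Statements on the series, on what has been measured and on what is new or still open speak of the compounds shown alone.

Compound 1 `O=C(C1=C(O)C(=O)N(CCCn2ccnc2)C1c1ccc(Br)cc1)c1ccccc1` gives the highest number of the three measured compounds in a functional assay on A549 cells (Homo sapiens) for antiproliferative activity, read by MTT assay, with a stated time of 72 h (a higher number here means a weaker inhibitor, a lower number a stronger inhibitor), at 73100 nM. Compound 2 `CCOC1=C(C(=O)c2ccccc2)C(c2ccc(Br)cc2)N(CCCn2ccnc2)C1=O` gives 35300 nM, and compound 3 `O=C(C1=C(Nc2ccc(F)cc2)C(=O)N(CCCn2ccnc2)C1c1ccc(Br)cc1)c1ccccc1` gives 27400 nM; the step of a 2.1-fold lower number from compound 1 to compound 2 (0.32 log units; beyond the scatter) and the step of a 2.7-fold lower number from compound 1 to compound 3 (0.43 log units; beyond the scatter) both point to stronger inhibition, while the step of a 1.3-fold lower number from compound 2 to compound 3 (0.11 log units; within the scatter) does not separate those two. Compound 4 `O=C(C1=C(Nc2ccc(I)cc2)C(=O)N(CCCn2ccnc2)C1c1ccc(Br)cc1)c1ccccc1` differs from compound 1 by (4-iodophenyl)amino in place of hydroxy on a double-bonded ring carbon. Among the compounds with values here, the closest precedent is compound 3, where a related change gave a 2.7-fold lower number from compound 1 to compound 3 (0.43 log units; beyond the scatter), so a lower number of similar modest size is expected for compound 4, as a 2.6-fold lower number from compound 1 to compound 4 (0.42 log units; beyond the scatter). Compound 4 is therefore estimated at 28000 nM, within a range of 12000 nM to 60000 nM in this assay.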

Compound 4, half-maximal inhibitory concentration: 24500 nM
Compound 4: the middle estimate sits 1.1-fold (0.06 log units) above what was measured; the measured number falls inside the stated range.
By their numbers in this assay, from the lowest: compounds 4, 3 and 2 (each within the scatter of the next); then compound 1.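

In this assay, iodo in place of fluoro on the aromatic ring of the amino substituent makes no difference beyond the scatter (a 1.1-fold lower number from compound 3 to compound 4 (0.05 log units; within the scatter)). A second halogenated phenylamino group keeps the gain over hydroxy (a 3.0-fold lower number from compound 1 to compound 4 (0.47 log units; beyond the scatter)), yet it is not separated from the much smaller ethoxy (a 1.4-fold lower number from compound 2 to compound 4 (0.16 log units; within the scatter)). No measurement shown gives a reason for these results. Still open, as far as these compounds go, is whether the ring halogen matters at all, which a plain phenylamino group would test. From the compounds shown here alone, a 4-methoxyphenylamino group or a simple unsubstituted amine at this position also remains open.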